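The source may report more compounds than this note shows. Statements on the series, on what has been measured and on what is new or still open speak of the compounds shown alone.

Measured so far:
- compound 1, `CC#CC(=O)Nc1ccccc1Nc1ccc2c(C(=O)c3cc(OC)cc(OC)c3)c[nH]c2n1`: 602 nM
- compound 2, `C=CC(=O)N1CCN(CCn2cc(-c3cc(OC)cc(OC)c3)c3cnc(NC)nc32)CC1`: > 10000 nM
- compound 3, `CC#CC(=O)N1CCN(CCCn2cc(-c3cc(OC)cc(OC)c3)c3cnc(NC)nc32)CC1`: > 10000 nM

All three were tested in a functional assay on Hep 3B2 cells (Homo sapiens) for antiproliferative activity, with a stated time of 72 h; on this read-out higher numbers stand for weaker inhibition and lower numbers for stronger inhibition. Compound 1 gives the only numeric result of the set, 602 nM. For compound 2 the assay reports only a limit, > 10000 nM, and not a number. For compound 3 the assay likewise reports only a limit, > 10000 nM. Two of the three results therefore sit at the limit of this assay (the limit of > 10000 nM in this assay, at which 2 of the 3 values shown sit), so compound 1 is the single point from which any comparison can start.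

Compound 4, `C=CS(=O)(=O)Nc1ccccc1Nc1ccc2c(C(=O)c3cc(OC)cc(OC)c3)c[nH]c2n1`, is built on the same core as compound 1 and differs from it in one place: vinylsulfonyl in place of (prop-1-yn-1-yl)carbonyl on a nitrogen on an aromatic ring. Going by the values given here, no pair of measured compounds shows this or any other single change, so there is no measured step to lean on; compounds 2 and 3 share neither the core nor the change with compound 1. With a prop-1-yn-1-ylcarbonyl group giving way to a vinylsulfonyl group, the expectation is a modest loss of potency, a step of a 2.5-fold higher number from compound 1 to compound 4 (0.40 log units; beyond the scatter) from compound 1. Compound 4 is estimated at 1500 nM in this assay, with a range from 300 nM to 8000 nM.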

Compound 4, half-maximal inhibitory concentration: 1030 nM
Estimate against measurement, compound 4: 1.5-fold (0.16 log units) above; the measured number falls inside the stated range.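

In this assay, going by these compounds alone, putting vinylsulfonyl in place of (prop-1-yn-1-yl)carbonyl on a nitrogen on an aromatic ring gives a 1.7-fold higher number from compound 1 to compound 4 (0.23 log units; within the scatter), the first step in this set that can be read between two compounds differing in one place. This step lies within the scatter, so compound 1 and compound 4 cannot be told apart here, and this position accepts the exchange of these two groups, each of 5 heavy atoms, without a measurable difference in this read-out. Nothing measured here gives a property of either group that could account for this result.

Whether a plain acetyl group or an unsubstituted amine on that same nitrogen would give a similar number stays open, so the compounds shown do not tell whether this position would accept any group or only groups like these two. Also open, as far as these compounds go, is whether the same exchange would give a similar step on a different core, since this single pair speaks only for the core of compound 1.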